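This account rests on a few compounds, and the source may have more. Where it says the series, first, only, none or still open, it means among the compounds named here.

Measured compounds:
Compound 1, `CCCCC#Cc1ccc(S(=O)(=O)Nc2cccc(-c3csc(NC(C)=O)n3)c2)cc1`: in a functional assay on A-375 cells (Homo sapiens) for antiproliferative activity, read by trypan blue exclusion, with a stated time of 48 h, tested at 10 uM (a higher number here means a weaker effect of the compound at the concentration tested, a lower number a stronger effect), compound 1 gives < 1%, which is a limit of the assay and not a number (the limit of < 1% in this assay, at which 1 of the 3 values shown sits).
Compound 2, `CC(=O)Nc1nc(-c2cccc(NS(=O)(=O)c3ccc(C#CCO)cc3)c2)cs1`: compound 2 gives 48.8%.
Compound 3, `C#Cc1ccc(S(=O)(=O)Nc2cccc(-c3csc(NC(C)=O)n3)c2)cc1`: compound 3 gives 1.2%.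

Of the two numbers shown, compound 3 holds the lower one; its nearest neighbour is compound 2, and the step of a number 47.6 percentage points lower from compound 2 to compound 3 (beyond the scatter) is large. The step of a number at least 0.2 percentage points higher from compound 1 to compound 3 (that floor lies within the scatter) has a floor that lies within the scatter, so it cannot be called a change.

Compound 4, `CC(=O)Nc1nc(-c2cccc(NS(=O)(=O)c3ccc(C#CCCc4ccccc4)cc3)c2)cs1`, is not yet measured. It differs from compound 3 by phenethyl in place of hydrogen on a triple-bonded carbon. Among the compounds with values here, two measured steps bear on this position on the triple-bonded carbon. Hydroxymethyl there, seen through a number 47.6 percentage points lower from compound 2 to compound 3 (beyond the scatter), moved the read-out a long way; butyl there, seen through a number at least 0.2 percentage points higher from compound 1 to compound 3 (that floor lies within the scatter), gave nothing resolvable from the scatter. Phenethyl, like butyl, brings no hydrogen-bond donor or acceptor, so the expected step of a number 0.8 percentage points higher from compound 3 to compound 4 (within the scatter) is none beyond the scatter. The estimate for compound 4 is 2%, expected to lie between 0% and 12%.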

Compound 4, a percentage reported as activity, at one concentration (the size of the read-out at that concentration, not a potency): < 1%
Compound 4: only a limit was reported (the forecaster's own chance of this, stated with the estimate: 40%); middle value at least 1 percentage points from the limit.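

In this assay compound 4 gives < 1%, which is a limit of the assay and not a number: the limit of < 1% in this assay, at which 2 of the 4 values shown sit.

The step of a number at least 0.2 percentage points lower from compound 3 to compound 4 (that floor lies within the scatter) has a floor that does not separate phenethyl from hydrogen on this triple-bonded carbon, so a chain ending in a six-membered aromatic ring joins butyl in showing no resolvable change; the step between the two limits cannot be read. The step of a number at least 47.8 percentage points lower from compound 2 to compound 4 (beyond the scatter) is large, and among the compounds shown, compound 2, with its hydroxymethyl, now stands apart from compounds 1, 3 and 4.

Going by these compounds, whether that gap belongs to the hydroxy alone stays open, and an amine or a carboxylic acid on the same saturated chain carbon would bear on it. Any order among compounds 1, 3 and 4 also stays open, with two of them at the limit.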